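Cytotoxicity notes: aryl exchange at the amide carbonyl

The compounds below may be only part of what the source reports. "The series", "measured", "known", "first", "only" and "open" are said of these compounds alone.

Of the compounds shown here, two have been measured. Compound 1 `Cc1ccc(N(C(=O)c2ccccc2[N+](=O)[O-])C(=S)OCCN2C(=O)c3ccccc3C2=O)cc1` in an ADME assay on MT4 cells (Homo sapiens) for cytotoxicity, read by MTT assay (on this read-out lower numbers stand for higher toxicity in this test and higher numbers for lower toxicity in this test), gives 100000 nM. Compound 2 `O=C1c2ccccc2C(=O)N1CCOC(=S)N(C(=O)c1ccc(F)cc1F)c1ccc(Cl)cc1` in this assay gives 52000 nM. Compound 2 holds the lowest of the two numbers; its nearest neighbour is compound 1, and the gap between them lies within the scatter, so no order between the two can be read. Among the compounds with values here, no pair of measured compounds differing in a single place is available, so no measured step exists to lean on.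

Compound 3 `COc1cccc(OC)c1C(=O)N(C(=S)OCCN1C(=O)c2ccccc2C1=O)c1ccc(Cl)cc1` is not yet measured. It differs from compound 2 by 2,6-dimethoxyphenyl in place of 2,4-difluorophenyl on a carbonyl carbon. With both measured numbers sitting within the scatter of each other, nothing points to a direction, and the expected step in this assay is a 1.2-fold higher number from compound 2 to compound 3 (0.06 log units; within the scatter), not beyond the scatter. Compound 3 is accordingly estimated at 60000 nM in this assay, within 25000 nM to 150000 nM.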

Compound 3, half-maximal cytotoxic concentration: 69000 nM
The estimate for compound 3 lay 1.2-fold (0.06 log units) below the measured number; measured number inside the range.
By their numbers in this assay, from the lowest: compounds 2, 3 and 1 (each within the scatter of the next).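

In this assay, the exchange on a carbonyl carbon now has its first measured single-place step: 2,6-dimethoxyphenyl in place of 2,4-difluorophenyl gives a 1.3-fold higher number from compound 2 to compound 3 (0.12 log units; within the scatter), so the two compounds cannot be told apart at this position. The entering group carries hydrogen-bond acceptors that the leaving group lacks, and this difference leaves the two numbers within the scatter of each other. No measurement at hand accounts for this reading.

Still open, as far as these compounds go, is whether an amine or a carboxylic acid in place of the aryl group on this carbonyl carbon would give a number beyond the scatter. The other places of the shared core have no single-place step among these compounds, so their contribution to the read-out remains unknown.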